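Ring Ether Amide in Place of a Carbamate

The source may report more compounds than this note shows. Statements on the series, on what has been measured and on what is new or still open speak of the compounds shown alone.

Compound 1 `O=C(Nc1ccc(OC(F)(F)F)cc1)NC1CCN(C(=O)C2CCOCC2)CC1` gives 91 ug/mL.
Compound 2 `CCOC(=O)N1CCC(NC(=O)Nc2ccc(OC(F)(F)F)c(F)c2)CC1` gives 0.35 ug/mL.

These two compounds were measured in a physicochemical assay for solubility, read by mass spectrometry, in phosphate buffer, with a stated time of 24 h, at pH 7.4; on this read-out lower numbers stand for lower solubility and higher numbers for higher solubility. Compound 2 stands lowest of the two numbers; its nearest neighbour, compound 1, sits far above it, a gap well beyond the scatter of repeated measurements. The new compound 3 `O=C(Nc1ccc(OC(F)(F)F)c(F)c1)NC1CCN(C(=O)[C@@H]2CCOC2)CC1` is reached from compound 2 by one change: oxolan-3-yl in place of ethoxy on a carbonyl carbon. Within the data shown here, no pair of measured compounds differing in a single place is available, so the size of this step cannot be read directly. Still, compound 1 shows that a carbonyl carrying a saturated oxygen ring can sit alongside a high reading of 91 ug/mL, and compound 3 carries a ring of that kind. A clear rise is therefore expected, though the extra fluorine on the aryl ring of compound 3 makes it only a loose guide. Compound 3 is estimated at 20 ug/mL, within a range from 3 ug/mL to 80 ug/mL. This estimate means a step of a 57-fold higher number from compound 2 to compound 3 (1.76 log units; beyond the scatter), expected to lie beyond the scatter.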

Compound 3, solubility: 61 ug/mL
Estimate against measurement, compound 3: 3.1-fold (0.48 log units) below; low and high end bracket the measured number.
By their numbers in this assay, from the lowest: compound 2; then compounds 3 and 1 (each within the scatter of the next).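

In this assay, putting oxolan-3-yl in place of ethoxy on the carbonyl carbon gives a 170-fold higher number from compound 2 to compound 3 (2.24 log units; beyond the scatter) with the rest of the molecule unchanged. Among these compounds, this is the first step here that can be read directly, and it shows that the group on this carbonyl carbon, whose other neighbour is an amide-type nitrogen in a ring, can move the reading a long way. No measurement at hand gives the reason for this step.

Still open, from the compounds shown here alone, is whether the ring or its oxygen matters more, which cyclopentyl, a ring of carbon only, could test at this place. Also open, going by these compounds, are how propoxy, a longer chain, or pyrrolidin-3-yl, a ring amine, would read here, and what the other mirror-image form of oxolan-3-yl would give.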